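Pyridine to Pyrazine on the Amide of Compound 2

The source may report more compounds than this note shows. Statements on the series, on what has been measured and on what is new or still open speak of the compounds shown alone.

Compounds measured so far:
Compound 1, `CCCCNc1nc(N)nc2c1CN(Cc1ccccc1)CC2`, 0.06 uM
Compound 2, `CCCCNc1nc(N)nc2c1CN(C(=O)c1ccccn1)CC2`, 2.9 uM

In an assay on HEK293 cells for agonist activity at Toll-like receptor 8 (Homo sapiens), read by a luciferase reporter, with a stated time of 6 h (a higher number here means that more compound is needed for the effect, a lower number that less compound is needed), compound 2 gives the highest of the two numbers; its nearest neighbour, compound 1, lies well apart, as the step of a 48-fold higher number from compound 1 to compound 2 (1.68 log units; beyond the scatter) shows. Compound 3, `CCCCNc1nc(N)nc2c1CN(C(=O)c1cnccn1)CC2`, is not yet measured. It differs from compound 2 by pyrazin-2-yl in place of pyridin-2-yl on a carbonyl carbon.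

For the measured compounds named here, no measured step bears directly on this change: the only step in hand, a 48-fold higher number from compound 1 to compound 2 (1.68 log units; beyond the scatter), swaps benzyl for (pyridin-2-yl)carbonyl on the ring amine nitrogen, a much larger alteration than the exchange of one ring for another on the carbonyl carbon. Since the amide arrangement of compound 2 is kept, the number for compound 3 is expected to stay near that of compound 2, with a step of a 1.0-fold higher number from compound 2 to compound 3 (0.01 log units; within the scatter) that may not exceed the scatter. Compound 3 is estimated at 3 uM, within 1 uM to 10 uM.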

Compound 3, minimum effective concentration: 2.2 uM
For compound 3 the middle estimate is 1.4-fold (0.13 log units) above the measured one, within the range that was stated.
By their numbers in this assay, from the lowest: compound 1; then compounds 3 and 2 (each within the scatter of the next).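

In this assay, the step of a 1.3-fold lower number from compound 2 to compound 3 (0.12 log units; within the scatter) shows that on this carbonyl carbon pyrazin-2-yl can stand in place of pyridin-2-yl without a change that can be told from the scatter. The step of a 37-fold higher number from compound 1 to compound 3 (1.56 log units; beyond the scatter) is large, as is a 48-fold higher number from compound 1 to compound 2 (1.68 log units; beyond the scatter), so the wide gap to compound 1 holds with either ring on the carbonyl carbon, and swapping one of these rings for the other does not close it. No measured evidence at hand explains either result.

The compounds shown leave open whether a plain phenyl ring, or a methyl group with no ring at all, on this carbonyl carbon would give a number in the same range. They also leave open whether any group on the carbonyl carbon can come close to compound 1, at 0.06 uM.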